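This account rests on a few compounds, and the source may have more. Where it says the series, first, only, none or still open, it means among the compounds named here.

Measured so far in a functional assay on HEL cells (Homo sapiens); a higher number here means that more compound is tolerated, a lower number that less compound is tolerated:
- compound 1 `C=C(C)C(=O)NC(=O)NC1=CS(=O)(=O)O[C@@]12[C@@H](CO[Si](C)(C)C(C)(C)C)O[C@@H](n1cc(C)c(=O)n(C)c1=O)[C@@H]2O[Si](C)(C)C(C)(C)C`: 1200 nM
- compound 2 `CCOC(=O)CNC(=O)NC1=CS(=O)(=O)O[C@@]12[C@@H](CO[Si](C)(C)C(C)(C)C)O[C@@H](n1cc(C)c(=O)n(C)c1=O)[C@@H]2O[Si](C)(C)C(C)(C)C`: 13000 nM

Compound 2 stands highest of the two numbers in this assay, at 13000 nM. Compound 3 `Cc1cn([C@@H]2O[C@H](CO[Si](C)(C)C(C)(C)C)[C@@]3(OS(=O)(=O)C=C3NC(=O)c3ccccc3)[C@H]2O[Si](C)(C)C(C)(C)C)c(=O)n(C)c1=O` is not yet measured. The change is phenyl in place of ((ethoxycarbonyl)methyl)amino on a carbonyl carbon. Within the data shown here, only one measured step bears on this: an 11-fold higher number from compound 1 to compound 2 (1.03 log units; beyond the scatter), a large step beyond the scatter. It concerns the (ethoxycarbonyl)methyl group, which is also part of what leaves in compound 3. One step is thin evidence, but it shows that this side of the molecule can move the number. A smaller step towards a lower number is expected in this assay, as compound 1, which also lacks that group, gives 1200 nM. The expected change is a 2.6-fold lower number from compound 2 to compound 3 (0.41 log units; beyond the scatter). For compound 3 the estimate is 5000 nM, with an expected range of 1300 nM to 19000 nM.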

Compound 3, half-maximal cytotoxic concentration: 9700 nM
Estimate against measurement, compound 3: 1.9-fold (0.29 log units) below; the range from low to high includes it.
By their numbers in this assay, from the lowest: compound 1; then compounds 3 and 2 (each within the scatter of the next).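

In this assay, phenyl in place of ((ethoxycarbonyl)methyl)amino on a carbonyl carbon gives a 1.3-fold lower number from compound 2 to compound 3 (0.13 log units; within the scatter), so this position accepts two very different groups with no change beyond the scatter. Against compound 1, phenyl in place of ((1-methylethenyl)carbonyl)amino gives an 8.1-fold higher number from compound 1 to compound 3 (0.91 log units; beyond the scatter); among these three compounds, the lower number therefore belongs to compound 1 alone, rather than to every group lacking the (ethoxycarbonyl)methyl part. No measurement shown accounts for the difference between compound 1 and the other two.

On these data alone, it remains open whether the number of compound 1 depends on the carbon-carbon double bond of its (1-methylethenyl)carbonyl group, which a saturated 2-methylpropanoyl group would test. Also open, as far as these compounds go, is how a carboxylic acid or a simple amine would read at this position.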